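Nitro for Bromo on an Aryl Amide Series

The compounds below may be only part of what the source reports. "The series", "measured", "known", "first", "only" and "open" are said of these compounds alone.

Measured compounds:
Compound 1, `COc1cc2c(Oc3ccc(NC(=O)c4nn(-c5ccc([N+](=O)[O-])cc5)c(=O)c5ccccc45)cc3F)ccnc2cc1OCCCN1CCCC1`: 1240 nM
Compound 2, `COc1cc2c(Oc3ccc(NC(=O)c4nn(-c5ccc(Br)cc5)c(=O)c5ccccc45)cc3F)ccnc2cc1OCCCN1CCCCC1`: 410 nM

The two measured compounds were tested in a functional assay on NCI-H460 cells (Homo sapiens) for cytotoxicity, read by MTT assay, with a stated time of 72 h; on this read-out higher numbers stand for weaker inhibition and lower numbers for stronger inhibition. Compound 1 gives 1240 nM and compound 2 gives 410 nM. Among the compounds with values here, on these two numbers compound 2 stands lowest, with compound 1 as its only neighbour, a gap that lies beyond the usual scatter. The two differ in more than one place, so the gap cannot be assigned to a single change.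

Compound 3, `COc1cc2c(Oc3ccc(NC(=O)c4nn(-c5ccc([N+](=O)[O-])cc5)c(=O)c5ccccc45)cc3F)ccnc2cc1OCCCN1CCCCC1`, has not yet been measured. It is obtained from compound 2 by a single change: nitro in place of bromo on an aromatic carbon — nitro in place of bromo on an aromatic carbon. Within the data shown here, no measured pair shows this exact exchange on an otherwise identical scaffold. Compound 1 also carries the nitro group, and its value sits well above that of compound 2, but compound 1 differs from compound 3 elsewhere, so its number can only be a loose guide. The step from compound 2 to compound 3 is expected to be a 2.0-fold higher number from compound 2 to compound 3 (0.29 log units; within the scatter), moving toward weaker inhibition. Compound 3 is therefore estimated at 800 nM, within a range from 350 nM to 1800 nM.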

Compound 3, half-maximal inhibitory concentration: 1300 nM
Compound 3: the middle estimate sits 1.6-fold (0.21 log units) below what was measured; the range from low to high includes it.
By their numbers in this assay, from the lowest: compound 2; then compounds 1 and 3 (each within the scatter of the next).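

In this assay, the change from 4-bromophenyl to 4-nitrophenyl, with the rest of the molecule held constant, gives a 3.2-fold higher number from compound 2 to compound 3 (0.50 log units; beyond the scatter) and so shows that this position alone can shift the number beyond the scatter. With the nitro group in place, piperidin-1-yl in place of pyrrolidin-1-yl at the end of the chain gives a 1.0-fold higher number from compound 1 to compound 3 (0.02 log units; within the scatter) and stays within the scatter, so among these compounds only the exchange on the aromatic ring produces a step beyond it. Nothing measured here accounts for the step from bromo to nitro.

From the compounds shown here alone, it remains open whether the two chain-end rings would also match each other with bromo on the aromatic ring, and whether a morpholine at the end of the chain would fit with them. Only bromo and nitro are shown at the aromatic position, so it is also unknown where a chloro, methoxy or amino group would fall relative to these two.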